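The source may hold more compounds than are shown below. What is called first, only, known or untested is meant among the compounds shown, and "the series" means these compounds.

Compound 1 `ClCc1ccccc1Cn1cnc2c(Cl)nc(Cl)nc21`: 5240 nM in a functional assay on UACC-62 cells (Homo sapiens) for cytotoxicity, read by sulforhodamine B assay, with a stated time of 48 h; on this read-out lower numbers stand for higher toxicity in this test and higher numbers for lower toxicity in this test. Compound 2 `ClCc1ccccc1Cn1cnc2c(Cl)ncnc21`: 28200 nM. Compound 3 `ClCc1cccc(Cn2cnc3ncnc(Cl)c32)c1`: 38900 nM.

Compound 1 and compound 2 are built on one core, compound 3 on another; the difference between the two cores is not broken down here. Compound 2 and compound 3 give numbers that lie within the usual scatter of each other, whereas compound 1 gives a far lower number than compound 3, which in this test means a more toxic compound. Within the core of compound 2, the only change from compound 2 to compound 1 is chloro in place of hydrogen on an aromatic carbon, and it gave a 5.4-fold lower number from compound 2 to compound 1 (0.73 log units; beyond the scatter). Compound 4 `ClCc1cccc(Cn2cnc3nc(Cl)nc(Cl)c32)c1`, not yet measured, carries the same change on the core of compound 3: chloro in place of hydrogen on an aromatic carbon. The surroundings of the place are the same in both pairs, so it is the same change. On the strength of the step of a 5.4-fold lower number from compound 2 to compound 1 (0.73 log units; beyond the scatter), compound 4 is expected to move by a 5.2-fold lower number from compound 3 to compound 4 (0.71 log units; beyond the scatter). The estimate for compound 4 in this assay is 7500 nM, with a likely range from 3000 nM to 20000 nM.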

Compound 4, concentration lethal to 50% of the cells: 4670 nM
Compound 4: the middle estimate sits 1.6-fold (0.21 log units) above what was measured; the measured number falls inside the stated range.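

In this assay, chloro in place of hydrogen on the aromatic carbon between two ring nitrogen atoms gave an 8.3-fold lower number from compound 3 to compound 4 (0.92 log units; beyond the scatter), and on this read-out a lower number means a more toxic compound. Set beside the earlier step, the same change lowers the number on both cores by a similar amount: the same change on two cores in this assay, a 5.4-fold lower number (0.73 log units; beyond the scatter) from compound 2 to compound 1 and an 8.3-fold lower number (0.92 log units; beyond the scatter) from compound 3 to compound 4, 1.5-fold (0.19 log units) apart, within the scatter of two such steps This shows that the step carried over between these two cores in this one cell test, but it rests on only two pairs of compounds and does not show that it would hold on a further core or explain how chloro produces the shift.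

The compounds shown carry only chloro or hydrogen at this place, so it remains open how an amine, a methoxy group or a methyl group there would compare. As far as these compounds go, a chloromethyl group is present in all of them, so the effect of a plain methyl or a hydroxymethyl group in its stead also remains open.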